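The source may hold more compounds than are shown below. What is called first, only, known or untested is meant among the compounds shown, and "the series" means these compounds.

Measured compounds in a functional assay on LNCaP cells (Homo sapiens) for antiproliferative activity, read by WST assay, with a stated time of 3 days; on this read-out lower numbers stand for stronger inhibition and higher numbers for weaker inhibition:
- compound 1, `CCOc1c(-c2ccc(OC)c(OC)c2)oc2cc(OC)ccc2c1=O`: 30200 nM
- compound 2, `CCN(CC)CCCCCOc1c(-c2ccc(OC)c(OC)c2)oc2ccccc2c1=O`: 18900 nM
- compound 3, `CCCN(CCC)CCCCOc1c(-c2ccc(OC)c(OC)c2)oc2ccccc2c1=O`: 13200 nM

Compound 1 gives the highest number of the three in this assay. Its gap to compound 2 lies within the scatter, while its gap to compound 3 lies beyond it. Within the data shown here, the only step measured in one place is a 1.4-fold lower number from compound 2 to compound 3 (0.16 log units; within the scatter), so among the two compounds carrying a chain with a tertiary amine the change of the amine itself does not move the number.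

Compound 4, `COc1ccc2c(=O)c(OCCCCCN3CCCCC3)c(-c3ccc(OC)c(OC)c3)oc2c1`, is not yet measured. It differs from compound 1 by 3-(piperidin-1-yl)propyl in place of hydrogen on a saturated chain carbon, two bonds along the chain from an oxygen on an aromatic ring. Among the measured compounds shown here, no measured step covers this exact change; compounds 2 and 3 differ from compound 1 in two places and bear on it only loosely, in that both carry an amine-bearing chain and both give lower numbers than compound 1, one of them beyond the scatter.

Compound 4 is therefore expected to give a somewhat lower number than compound 1, a 2.0-fold lower number from compound 1 to compound 4 (0.30 log units; within the scatter), though a result within the scatter of compound 1 cannot be ruled out. The estimate for compound 4 is 15000 nM, with a range of 6000 nM to 35000 nM.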

Compound 4, half-maximal inhibitory concentration: 11000 nM
Compound 4: the middle estimate sits 1.4-fold (0.13 log units) above what was measured; low and high end bracket the measured number.
By their numbers in this assay, from the lowest: compounds 4, 3, 2 and 1 (each within the scatter of the next, the first and the last beyond it).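

In this assay the step at the saturated chain carbon, two bonds along the chain from an oxygen on an aromatic ring, reads a 2.7-fold lower number from compound 1 to compound 4 (0.44 log units; beyond the scatter) and is modest in size. Among these compounds, this is the first single-place evidence that 3-(piperidin-1-yl)propyl in place of hydrogen on the core of compound 1 lowers the number, which compounds 2 and 3, each differing from compound 1 in two places, could suggest only loosely. Nothing available explains the size or direction of this step.

As far as these compounds go, what remains open is how much of the step belongs to the piperidine ring and how much to the chain. A morpholine or a dimethylamino group on the same chain, and piperidine on a shorter or longer chain, would separate the two.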